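Ester Chain Length and Adenosine Receptor A3 Inhibition

A few compounds are considered here, and "the series" means these few. Any claim that something is new, unique, unknown or untested is made for them only; others in the source may bear on it.

Measured compounds:
compound 1 `COC(=O)C1=C(C)N(C)C(=O)NC1c1cccs1`: 15%
compound 2 `CCOC(=O)C1=C(C)N(C)C(=O)NC1c1cccs1`: 2%
compound 3 `CCSC(=O)C1=C(C)NC(=O)NC1c1ccoc1`: 1%

In an assay on membranes from HeLa cells for displacement of a labelled ligand from adenosine receptor A3 (Homo sapiens), read by scintillation counting, with a stated time of 180 min, tested at 1 uM (a lower number here means less inhibition, a higher number more inhibition at the concentration tested (going by the name of the read-out)), compound 1 gives 15%. The change methyl in place of hydrogen on a saturated chain carbon bound to an oxygen next to a carbonyl group gives a number 13 percentage points lower from compound 1 to compound 2 (beyond the scatter). Compound 3 gives 1%; the difference between its core and that of compound 1 is not broken down here. Compound 4 `CC1=C(C(=O)SC(C)C)C(c2ccoc2)NC(=O)N1` is not yet measured. It arises from compound 3 by methyl in place of hydrogen on a saturated chain carbon bound to a saturated chain carbon and a sulfur, the same kind of change as before, but the carbon carrying the new methyl is bound to a saturated chain carbon and a sulfur rather than to an oxygen next to a carbonyl group. Because compound 3 already sits at 1%, little room for a further fall remains, so the expected step is no change at the digits printed from compound 3 to compound 4 (within the scatter). Compound 4 is estimated at 1%, between -6% and 8%.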

Compound 4, a percentage reported as inhibition, at one concentration (the size of the read-out at that concentration, not a potency): 3%
Beside the measured number, compound 4's estimate is 2 percentage points below it; measured number inside the range.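

In this assay, adding the methyl gives a number 2 percentage points higher from compound 3 to compound 4 (within the scatter), so the step seen on the core of compound 1 does not carry over in size to this core: the same change on two cores in this assay, a number 13 percentage points lower (beyond the scatter) from compound 1 to compound 2 and a number 2 percentage points higher (within the scatter) from compound 3 to compound 4, 15 percentage points apart, beyond the scatter of two such steps. This does not show what lies behind the gap, as the new methyl sits on a carbon bound to a sulfur in one case and on a carbon bound to an oxygen in the other, and the cores differ as well. Compound 3 gives 1%, which leaves no room on the scale for a fall of the earlier size.

The compounds shown leave open how a longer chain, such as butyl, or a chain ending in an amine would read at this place on either core.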